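The compounds below may be only part of what the source reports. "The series", "measured", "known", "first", "only" and "open" are said of these compounds alone.

Measured in a functional assay on the whole organism (strain Wistar Albino) for inhibition, with Rattus norvegicus as the target, read by paw edema, with a stated time of 3 h, at a dose of 20 mg/kg (a higher number here means more inhibition at the dose given (going by the name of the read-out), a lower number less inhibition), so far:
compound 1, `COc1ccc(Cl)c(-c2nnc3sc(Cc4c[nH]c5ccc(OC)cc45)nn23)c1`, gives 21.4%
compound 2, `COc1ccc2[nH]cc(Cc3nn4c(Cc5ccc(OC)c(OC)c5)nnc4s3)c2c1`, gives 19.1%
compound 3, `COc1ccc(Cl)c(-c2nnc3sc(Cc4c[nH]c5ccccc45)nn23)c1`, gives 21.4%

Compound 1 and compound 3 share one core and differ in a single place: hydrogen in place of methoxy on an aromatic carbon. That change produced no change at the digits printed from compound 1 to compound 3 (within the scatter). Compound 2 is built on a different core; how its core differs from the core of compound 1 is not broken down here, and the values of compound 1 and compound 2 lie within the usual scatter of each other, as do those of compound 2 and compound 3.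

Compound 4, `COc1ccc(Cc2nnc3sc(Cc4c[nH]c5ccccc45)nn23)cc1OC`, has not yet been measured in this assay. It differs from compound 2 by hydrogen in place of methoxy on an aromatic carbon. The place of this change reads the same, word for word, as in the pair compound 1 to compound 3, so it is the same change carried onto the core of compound 2. Among the compounds with values here, since that change in the first pair gave no change at the digits printed from compound 1 to compound 3 (within the scatter), the step from compound 2 to compound 4 is expected to be of similar size, namely a number 0.1 percentage points lower from compound 2 to compound 4 (within the scatter). Compound 4 is therefore estimated at 19%, expected to fall between 11% and 27%. This expectation rests on a single measured pair, compound 1 and compound 3, and on nothing else.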

Compound 4, a percentage reported as inhibition, in the whole organism at one dose (the size of the read-out at that dose, not a potency): 28.3%
Compound 4: middle estimate off by 9.3 percentage points, on the low side; measured number above the stated range.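

In this assay hydrogen in place of methoxy on a second core gives a number 9.2 percentage points higher from compound 2 to compound 4 (within the scatter), and this step does not stand apart from the earlier one: the same change on two cores in this assay, no change at the digits printed (within the scatter) from compound 1 to compound 3 and a number 9.2 percentage points higher (within the scatter) from compound 2 to compound 4, 9.2 percentage points apart, within the scatter of two such steps. Across these two cores, then, the change carries over with no difference in size that can be told from the scatter, and neither step on its own can be told from no effect. This does not show that the two cores respond alike, since two pairs at a single dose and time are a thin basis and a real difference smaller than the scatter would go unseen.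

Among the compounds shown, only methoxy and hydrogen occupy this aromatic carbon, so it stays open whether any group there can move the inhibition of paw edema beyond the scatter. An amine, a carboxylic acid or a longer chain at the same place, set on both cores, would test that.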